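Trimming the amide side of compound 1 to a cyclopropyl

The compounds below may be only part of what the source reports. "The series", "measured", "known", "first", "only" and "open" are said of these compounds alone.

Of the compounds shown here, two from this series have been measured in an assay on CHO cells for displacement of a labelled ligand from histamine receptor H3 (Macaca mulatta); on this read-out lower numbers stand for stronger inhibition and higher numbers for weaker inhibition. Compound 1 `Cc1cc(NC(=O)C2CC3CCC2C3)ccc1N1CCC(N2CCCC2C)C1` gives 130 nM in this assay, the higher of the two numbers. Compound 2 `CC1CCCN1C1CCN(c2ccc(NC(=O)C3CCCO3)cc2)C1` gives 8.7 nM, a value well below that of compound 1 and outside the usual scatter; the two structures differ in more than one place, so the two values alone are all that can be said of that pair.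

For the measured compounds named here, compound 3 `Cc1cc(NC(=O)C2CC2)ccc1N1CCC(N2CCCC2C)C1` is derived from compound 1 by a single change: a group of 3 heavy atoms (3 carbon; one three-membered non-aromatic ring of carbon only) in place of a group of 7 heavy atoms (7 carbon; 2 five-membered non-aromatic rings of carbon only), on a carbonyl carbon, the carbonyl carbon being the one whose other neighbour is the amide-type nitrogen. The cyclopropyl thus replaces the larger bicyclic group while the rest of compound 1 is kept. Given that only compound 1 shares this core, the step is expected to be a moderate improvement, a 2.9-fold lower number from compound 1 to compound 3 (0.46 log units; beyond the scatter), rather than a change within the scatter. Compound 3 is therefore estimated at 45 nM, with a plausible range from 12 nM to 160 nM.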

Compound 3, inhibition constant: 17.7 nM
Estimate against measurement, compound 3: 2.5-fold (0.41 log units) above; measured number inside the range.
By their numbers in this assay, from the lowest: compound 2; then compound 3; then compound 1.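

In this assay, the group on the carbonyl carbon whose other neighbour is the amide-type nitrogen clearly affects the result: cyclopropyl in place of the larger group with 2 five-membered carbon rings gives a 7.3-fold lower number from compound 1 to compound 3 (0.87 log units; beyond the scatter) as a modest step beyond the usual scatter. For the compounds shown here, this is the only comparison here with the rest of the structure held fixed, and it shows that the larger group is not needed for a low number on this core, with neither group carrying hydrogen-bond donors or acceptors. Nothing at hand explains the step.

From the compounds shown here alone, a single step gives no trend with size, so it remains open whether a cyclobutyl, an isopropyl or a methyl on the same carbonyl carbon would continue or reverse this shift. Going by these compounds, it is equally open how an amine or a longer chain would fare there, and whether cyclopropyl would have a similar effect on the core of compound 2.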